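From a cyanophenyl amide to a methoxyphenyl amide

The compounds below may be only part of what the source reports. "The series", "measured", "known", "first", "only" and "open" are said of these compounds alone.

Compound 1 `O=C(Nc1ccc(Cl)c(-c2nc3ccccc3[nH]2)c1)c1ccc(F)cc1`: 251 nM
Compound 2 `O=C(Nc1ccc(Cl)c(-c2nc3ccccc3[nH]2)c1)c1ccc(Cl)cc1`: 224 nM
Compound 3 `N#Cc1ccc(C(=O)Nc2ccc(Cl)c(-c3nc4ccccc4[nH]3)c2)cc1`: 185 nM

In a functional assay on Shh Light II cells for inhibition of Sonic hedgehog protein (Mus musculus), read by reporter gene assay, with a stated time of 48 h, in the presence of a further agent that is not named here (a higher number here means a weaker inhibitor, a lower number a stronger inhibitor), compound 3 gives the lowest of the three numbers, yet its separation from compound 2 (a 1.2-fold lower number from compound 2 to compound 3 (0.08 log units; within the scatter)) and from compound 1 (a 1.4-fold lower number from compound 1 to compound 3 (0.13 log units; within the scatter)) lies within the scatter, as does a 1.1-fold lower number from compound 1 to compound 2 (0.05 log units; within the scatter); no order among the three is claimed. Compound 4 `COc1ccccc1C(=O)Nc1ccc(Cl)c(-c2nc3ccccc3[nH]2)c1` differs from compound 3 by 2-methoxyphenyl in place of 4-cyanophenyl on a carbonyl carbon. All three measured steps exchange one group on the 4-cyanophenyl part and leave the number essentially unchanged; none of them brings in a 2-methoxyphenyl, so the bearing on compound 4 is indirect. The expected change is a 1.6-fold higher number from compound 3 to compound 4 (0.21 log units; within the scatter), small and of uncertain direction. Compound 4 is therefore estimated at 300 nM, within 100 nM to 1000 nM.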

Compound 4, half-maximal inhibitory concentration: 876 nM
The estimate for compound 4 lay 2.9-fold (0.47 log units) below the measured number, and the stated range covers the measured number.
By their numbers in this assay, from the lowest: compounds 3, 2 and 1 (each within the scatter of the next); then compound 4.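

In this assay, within the data shown here, the aryl group on the carbonyl carbon proves able to shift the number, which the earlier compounds did not show: a 4.7-fold higher number from compound 3 to compound 4 (0.68 log units; beyond the scatter), a 3.9-fold higher number from compound 2 to compound 4 (0.59 log units; beyond the scatter) and a 3.5-fold higher number from compound 1 to compound 4 (0.54 log units; beyond the scatter). Exchanges among 4-fluorophenyl, 4-chlorophenyl and 4-cyanophenyl stayed within the scatter, whereas 2-methoxyphenyl in place of each gives a modest weakening beyond it. No measurement is available that explains this loss. The step changes both the group and where it sits on the ring, and the compounds shown cannot separate the two. From the compounds shown here alone, how an amine or a carboxylic acid on this ring would fare also remains open.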